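A Single Aromatic Swap in a Weakly Active Pair

This account rests on a few compounds, and the source may have more. Where it says the series, first, only, none or still open, it means among the compounds named here.

Of the compounds shown here, two from this series have been measured in a functional assay on DU-145 cells (Homo sapiens) for inhibition, read by trypan blue exclusion, with a stated time of 96 h; on this read-out higher numbers stand for weaker inhibition of growth and lower numbers for stronger inhibition of growth. Compound 1, `CCOc1ccc(/C=C(\C(=O)c2ccc(Cl)cc2)S(=O)(=O)Cc2ccc(F)cc2)cc1OC`, gives 50000 nM in this assay. Compound 2, `CC(=O)Oc1ccc(/C=C(\C(=O)c2ccc(Cl)cc2)S(=O)(=O)c2ccc(C)cc2)cc1`, gives 25000 nM in this assay. On the numbers measured, compound 2 stands nearest to compound 1, and the gap between them lies within the usual scatter of repeated measurements, so neither can be called stronger than the other; both sit in the same weak range.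

Compound 3, `Cc1ccc(S(=O)(=O)/C(=C/c2ccc(Cl)cc2)C(=O)c2ccc(Cl)cc2)cc1`, has not yet been measured. It differs from compound 2 in one place: chloro in place of acetoxy on an aromatic carbon. Among the measured compounds shown here, no step between measured compounds is available to guide the expectation, and compound 1 differs from compound 2 in more than one place, so only the two measured values themselves can be drawn upon. With nothing to suggest otherwise, the step from compound 2 to compound 3 in this assay is expected to be no larger than the scatter, in no particular direction, as no change at the digits printed from compound 2 to compound 3 (within the scatter). For compound 3 the estimated value in this assay is 25000 nM, with a range from 8000 nM to 80000 nM.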

Compound 3, concentration for 50% growth inhibition: 1000 nM
Compound 3: middle estimate off by 25-fold (1.40 log units), on the high side; the measured number lies below the stated range.
By their numbers in this assay, from the lowest: compound 3; then compounds 2 and 1 (each within the scatter of the next).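

Chloro in place of acetoxy, on an aromatic carbon para to a large group, gives the first step in this series that lies beyond the scatter in this assay: a 25-fold lower number from compound 2 to compound 3 (1.40 log units; beyond the scatter). The position is therefore not indifferent to what it carries, since the two measured compounds alone gave no sign that a single change could move the value by this much. Here an acetoxy group of four heavy atoms, with one double bond and two hydrogen-bond acceptors, gives way to a single chlorine, but nothing measured here tells which part of that difference accounts for the stronger inhibition of growth.

As far as these compounds go, what remains open is whether the gain comes from losing acetoxy or from gaining chloro, a question that a hydroxyl, a methoxy or an amine at the same position could help to separate. From the compounds shown here alone, it is also open whether the same change would produce a step of similar size on the rest of compound 1, which differs from compound 2 in more than one place.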